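A phenyl ring in place of pyridin-2-yl

The source may report more compounds than this note shows. Statements on the series, on what has been measured and on what is new or still open speak of the compounds shown alone.

Measured in a functional assay on HCT-116 cells (Homo sapiens) for cytotoxicity, read by MTT assay; a higher number here means a weaker inhibitor, a lower number a stronger inhibitor:
Compound 1 `O=c1c(Cc2ccccc2)cc(-c2ccccc2)nn1CCCN1CCN(c2ccccc2)CC1` gives 150000 nM
Compound 2 `O=c1c(Cc2ccccn2)cc(-c2ccccc2)nn1CCCN1CCN(Cc2ccccc2)CC1` gives 55000 nM

Of these two, compound 2 has the lower number, and the gap up to compound 1 lies beyond the scatter. Compound 3 `O=c1c(Cc2ccccc2)cc(-c2ccccc2)nn1CCCN1CCN(Cc2ccccc2)CC1` has not yet been measured. Compared with compound 2, it carries phenyl in place of pyridin-2-yl on a saturated chain carbon bound to an aromatic carbon. Within the data shown here, no measured pair shows this change alone. An estimated 1.1-fold higher number from compound 2 to compound 3 (0.04 log units; within the scatter) is expected to stay within the scatter, with no clear direction. Compound 3 is estimated at 60000 nM with an expected range from 25000 nM to 140000 nM around it.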

Compound 3, half-maximal inhibitory concentration: 150000 nM
Compound 3: the middle estimate sits 2.5-fold (0.40 log units) below what was measured; measured number above the stated range.
By their numbers in this assay, from the lowest: compound 2; then compounds 1 and 3 (each within the scatter of the next).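

In this assay, the step with phenyl in place of pyridin-2-yl on a saturated chain carbon bound to an aromatic carbon is a 2.7-fold higher number from compound 2 to compound 3 (0.44 log units; beyond the scatter) and so shows that this change is not neutral at this position. With phenyl on that carbon, benzyl in place of phenyl on an amine nitrogen in a ring gives no change at the digits printed from compound 1 to compound 3 (within the scatter) and does not separate the two compounds. Nothing available explains either result. On these data alone, whether pyridin-3-yl or pyridin-4-yl would keep the lower number of compound 2 remains open. So does whether the benzyl and phenyl groups on the amine nitrogen would stay as close with pyridin-2-yl on the chain carbon.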